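The compounds below may be only part of what the source reports. "The series", "measured", "known", "first", "only" and "open" are said of these compounds alone.

Working notes on the rhodanine-acetic acid series. In a functional assay on PC-3 cells (Homo sapiens) for cytotoxicity, read by MTT assay, with a stated time of 48 h (on this read-out higher numbers stand for weaker inhibition and lower numbers for stronger inhibition), compound 1 `O=C(O)CN1C(=O)/C(=C/c2nc3ccccc3n2Cc2ccc(F)cc2)SC1=S` gives 4860 nM, and compound 2 `O=C(O)CN1C(=O)/C(=C/c2nc3ccccc3n2Cc2ccc(Cl)cc2)SC1=S` gives 9670 nM. The change between them, (fluoro in place of chloro on an aromatic carbon), made a step of a 2.0-fold lower number from compound 2 to compound 1 (0.30 log units; within the scatter). Compound 3 `O=C(O)CN1C(=O)/C(=C/c2nc3ccc(Cl)cc3n2Cc2ccccc2F)SC1=S` gives 17300 nM; how its core differs from that of compound 2 is not broken down here. Compound 4 `O=C(O)CN1C(=O)/C(=C/c2nc3ccc(F)cc3n2Cc2ccccc2F)SC1=S` is still unmeasured and differs from compound 3 by fluoro in place of chloro on an aromatic carbon. This is the same kind of change as from compound 2 to compound 1, not the same: there the place is para to a large group, here it lies on a ring that is part of a fused system of two rings, meta and para to a fused ring. A step of similar size is expected, a 1.7-fold lower number from compound 3 to compound 4 (0.24 log units; within the scatter), resting on the earlier step of a 2.0-fold lower number from compound 2 to compound 1 (0.30 log units; within the scatter) being within the scatter. Compound 4 is therefore expected near 10000 nM, with a likely range from 4000 nM to 30000 nM.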

Compound 4, half-maximal inhibitory concentration: > 50000 nM
Compound 4: no number, only a limit (the forecaster's own chance of this, stated with the estimate: 15%); at least 5.0-fold (0.69 log units) between middle value and limit.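

In this assay, fluoro in place of chloro on an aromatic carbon does not carry over as one step: it gives a 2.0-fold lower number from compound 2 to compound 1 (0.30 log units; within the scatter) on one core and an at least 2.8-fold higher number from compound 3 to compound 4 (0.46 log units; beyond the scatter) on the other, and the two steps differ: the same change on two cores in this assay, a 2.0-fold lower number (0.30 log units; within the scatter) from compound 2 to compound 1 and an at least 2.8-fold higher number (0.46 log units; beyond the scatter) from compound 3 to compound 4, at least 5.7-fold (0.75 log units) apart, beyond the scatter of two such steps

Compound 4 gives > 50000 nM, which is a limit of the assay and not a number: the limit of > 50000 nM in this assay, at which 1 of the 4 values shown sits.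

These two pairs show that the step cannot be assumed to transfer between these cores, but they do not show whether the core or the place of the change decides its size, and they set no rule for the series.

From the compounds shown here alone, it remains open whether bromo or methoxy in place of the chloro of compound 3 would stay close to compound 3 or fall with compound 4. Going by these compounds, it is also open how compound 3 would compare with a plain hydrogen at that place.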